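The compounds below may be only part of what the source reports. "The series", "measured", "known", "first", "only" and "open" are said of these compounds alone.

Measured compounds:
Compound 1 `CN1CCN(CCCS(=O)(=O)c2ccc3nc(NC(=O)NC(=O)c4cc(C5CC5)ccc4Cl)sc3c2)CC1`: 0.33 nM
Compound 2 `COCCNCCCS(=O)(=O)c1ccc2nc(NC(=O)NC(=O)c3ccccc3Cl)sc2c1`: 8.6 nM
Compound 3 `Cc1ccnn1-c1ccc(Cl)c(C(=O)NC(=O)Nc2nc3ccc(S(=O)(=O)C4CCN(C)CC4)cc3s2)c1`: 33 nM

All three were tested in an assay on HEK293 cells for displacement of a labelled ligand from growth hormone secretagogue receptor type 1 (Homo sapiens), with a stated time of 60 min; on this read-out lower numbers stand for stronger inhibition and higher numbers for weaker inhibition. Among the three numbers, compound 1 has the lowest, and both other values lie beyond the usual scatter of this assay, so compound 1 is the strongest binder of the three. Compound 2 gives a clearly higher number, and compound 3 gives the highest of the set. The three compounds share one core, and each differs in the group attached to the carbonyl carbon and in the amine-bearing chain on the sulfonyl side.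

Compound 4 `CN1CCN(CCCS(=O)(=O)c2ccc3nc(NC(=O)NC(=O)c4cccc(-n5cccn5)c4Cl)sc3c2)CC1` differs from compound 1 in one place:
2-chloro-3-(1H-pyrazol-1-yl)phenyl in place of 2-chloro-5-cyclopropylphenyl on a carbonyl carbon

Among the measured compounds shown here, no measured pair shows this exact change, so its effect has to be judged from the whole set. The two compounds that do not carry the 2-chloro-5-cyclopropylphenyl group, compound 2 and compound 3, give higher numbers than compound 1, which suggests that changing this group costs binding. The step from compound 1 to compound 4 is therefore expected to be a moderate rise in this assay, a 9.1-fold higher number from compound 1 to compound 4 (0.96 log units; beyond the scatter), beyond the scatter. Compound 4 is estimated to give 3 nM, with a likely range from 0.6 nM to 15 nM.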

Compound 4, half-maximal inhibitory concentration: 8.8 nM
For compound 4 the middle estimate is 2.9-fold (0.47 log units) below the measured one; low and high end bracket the measured number.
By their numbers in this assay, from the lowest: compound 1; then compounds 2 and 4 (each within the scatter of the next); then compound 3.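

In this assay, putting 2-chloro-3-(1H-pyrazol-1-yl)phenyl in place of 2-chloro-5-cyclopropylphenyl on the carbonyl carbon gives a 27-fold higher number from compound 1 to compound 4 (1.43 log units; beyond the scatter), a large step beyond the scatter. Among the compounds shown here, this is the first pair in the set that differs in this one place only, since the earlier compounds also varied in the amine-bearing chain on the sulfonyl side, so it shows that this group alone can shift the read-out strongly while the rest of the molecule stays the same. Nothing available here accounts for the size or direction of this step.

The compounds shown leave open whether the rise belongs to the pyrazolyl ring itself or to where it stands, as the names differ in both the attached ring and its number on the phenyl ring. With the same methylpiperazine-bearing chain, 2-chloro-3-cyclopropylphenyl and 2-chloro-5-(1H-pyrazol-1-yl)phenyl would each change only one of these two features and so could separate them.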